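This account rests on a few compounds, and the source may have more. Where it says the series, first, only, none or still open, it means among the compounds named here.

Measured in an ADME assay on Caco-2 cells (Homo sapiens) for permeability, read by LC-MS, in the apical to basolateral direction, with a stated time of 60 min, at pH 6.5; a lower number here means that the compound crosses the layer more slowly, a higher number that the compound crosses the layer faster:
- Compound 1 `CC(C)(C)[C@@H](O)C(=O)N1CCS[C@H]1C(=O)NCc1cc(Cl)ccc1-n1cnnn1`: 5.2 10^-6 cm/s
- Compound 2 `O=C(NCc1cc(Cl)ccc1-n1cnnn1)[C@@H]1C[C@@H]2C[C@@H]2N1C(=O)[C@H](O)CC1CC1`: 3.6 10^-6 cm/s
- Compound 3 `Cc1cccc([C@@H](O)C(=O)N2N=CC[C@H]2C(=O)NCc2cc(Cl)ccc2-n2cnnn2)c1`: 9.7 10^-6 cm/s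

Compound 2, at 3.6 10^-6 cm/s, cannot be told apart from compound 1, at 5.2 10^-6 cm/s, as the two lie within the usual scatter of the measurement. Compound 3, at 9.7 10^-6 cm/s, reads higher than compound 2 by more than that scatter.

Compound 4 `O=C(NCc1cc(Cl)ccc1-n1cnnn1)[C@@H]1C[C@@H]2C[C@@H]2N1C(=O)[C@H](O)Cn1cccn1` has not been measured yet. It keeps the core of compound 2 and changes one group: 1H-pyrazol-1-yl in place of cyclopropyl on a saturated chain carbon, two bonds along the chain from a carbonyl carbon and an oxygen on a saturated carbon. Here 1H-pyrazol-1-yl stands in place of cyclopropyl on a saturated chain carbon, two bonds along the chain from a carbonyl carbon and an oxygen on a saturated carbon.

Among the compounds with values here, no two measured compounds differ in one place only, so the data offer no direct guide to this swap. In this assay, a small downward step is expected, and it may well stay within the scatter. The expected change is a 1.4-fold lower number from compound 2 to compound 4 (0.14 log units; within the scatter). For compound 4 the estimate is 2.6 10^-6 cm/s, with an expected range of 1 10^-6 cm/s to 6 10^-6 cm/s.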

Compound 4, apparent permeability: 0.45 10^-6 cm/s
Compound 4: the middle estimate sits 5.8-fold (0.76 log units) above what was measured; the whole stated range lies above it.
By their numbers in this assay, from the lowest: compound 4; then compounds 2, 1 and 3 (each within the scatter of the next, the first and the last beyond it).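

Within the data shown here, measured by this assay the change to 1H-pyrazol-1-yl in place of cyclopropyl gives an 8.0-fold lower number from compound 2 to compound 4 (0.90 log units; beyond the scatter) and provides the first comparison in this set between two compounds that differ in one place only. With the core held constant, this saturated chain carbon, two bonds along the chain from a carbonyl carbon and an oxygen on a saturated carbon, proves sensitive to the group it carries: the entering ring has two nitrogens and two hydrogen-bond acceptors, whereas cyclopropyl has neither. No measured evidence here gives a reason for the fall.

The compounds shown leave open whether the ring nitrogens matter or whether any five-membered ring here would give the same result, which a cyclopentyl or phenyl group at this place could help separate. On these data alone, whether the same change would have a similar effect on the cores of compound 1 and compound 3 also remains open.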